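The compounds below may be only part of what the source reports. "The series", "measured", "known", "first", "only" and "open" are said of these compounds alone.

The two measured compounds set the frame. Compound 1 `CCCCCCCC/C=C\CCCCCCC(=O)c1ccccn1` has no number in an assay on isolated protein for inhibition of Fatty-acid amide hydrolase 1 (Homo sapiens); a higher number here means a weaker inhibitor, a lower number a stronger inhibitor: compound 1 gives only the limit > 100000 nM, and the limit of > 100000 nM in this assay, at which 1 of the 2 values shown sits, notes this. For the measured compounds named here, compound 2 `CCCCCCCCCCCCCC(=O)C(F)(F)F` is the only one with a measured value; in this assay compound 2 gives 490 nM.

Compound 3 `CCCCCCCC/C=C\CCCCCCC(=O)c1nccn1C` is the unmeasured analogue of compound 1. The difference is 1-methyl-1H-imidazol-2-yl in place of pyridin-2-yl on a carbonyl carbon, with the rest of the chain kept. Going by the values given here, since compound 1 sits at a limit, no measured step exists to lean on, and the step of an at least 12-fold lower number from compound 1 to compound 3 (1.09 log units; beyond the scatter) is an expectation only: a move towards stronger inhibition, of a size that is uncertain but expected to be beyond the scatter. On that basis compound 3 is estimated at 8000 nM, within a range from 1000 nM to 100000 nM.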

Compound 3, inhibition constant: > 100000 nM
Compound 3 was reported as a limit; the forecaster's own chance of this, stated with the estimate: 30%; middle value at least 12-fold (1.09 log units) from the limit.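

Compound 1 and compound 3 both stand at a limit rather than a number in this assay, so no step between them can be read: the limit of > 100000 nM in this assay, at which 2 of the 3 values shown sit.

The compounds shown leave open whether 1-methyl-1H-imidazol-2-yl in place of pyridin-2-yl on a carbonyl carbon changes inhibition at all.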